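The compounds below may be only part of what the source reports. "The series", "measured", "known", "first", "only" and "open" are said of these compounds alone.

Compound 1 `CC(C)S(=O)(=O)NC(=O)c1ccc(Nc2nc(NC3(c4ccc(Cl)cc4)CC3)nc(OCC(F)(F)F)n2)cc1`: 31 nm/s
Compound 2 `CC(C)NCCS(=O)(=O)NC(=O)c1ccc(Nc2nc(NC3(c4ccc(Cl)cc4)CC3)nc(OCC(F)(F)F)n2)cc1`: 45 nm/s
Compound 3 `CC(C)(C)OC(=O)NCCS(=O)(=O)NC(=O)c1ccc(Nc2nc(NC3(c4ccc(Cl)cc4)CC3)nc(OCC(F)(F)F)n2)cc1`: 111 nm/s

In a physicochemical assay for permeability, using PAMPA, at pH 7.4 (a lower number here means that the compound crosses the layer more slowly, a higher number that the compound crosses the layer faster), compound 3 stands highest of the three: a 2.5-fold higher number from compound 2 to compound 3 (0.39 log units; beyond the scatter) and a 3.6-fold higher number from compound 1 to compound 3 (0.55 log units; beyond the scatter) are both beyond the scatter, while a 1.5-fold higher number from compound 1 to compound 2 (0.16 log units; within the scatter) stays within it. Compound 4 `CC(C)C(=O)NCCS(=O)(=O)NC(=O)c1ccc(Nc2nc(NC3(c4ccc(Cl)cc4)CC3)nc(OCC(F)(F)F)n2)cc1` differs from compound 3 by isopropyl in place of tert-butoxy on a carbonyl carbon. For the measured compounds named here, the step that bears on this is the one from compound 2 to compound 3, where the amine nitrogen went from isopropyl to tert-butoxycarbonyl, a 2.5-fold higher number from compound 2 to compound 3 (0.39 log units; beyond the scatter). Compound 4 keeps the carbonyl on that nitrogen but not the tert-butoxy, and a position between compound 2 and compound 3 is therefore expected, a modest step estimated as a 1.6-fold lower number from compound 3 to compound 4 (0.20 log units; within the scatter). Compound 4 is expected to give 70 nm/s in this assay, in the range 35 nm/s to 140 nm/s.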

Compound 4, apparent permeability: 13 nm/s
Compound 4: middle estimate off by 5.4-fold (0.73 log units), on the high side; the whole stated range lies above it.
By their numbers in this assay, from the lowest: compound 4; then compounds 1 and 2 (each within the scatter of the next); then compound 3.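

In this assay, for the compounds shown here, keeping the carbonyl on the nitrogen does not hold the higher number: isopropyl in place of tert-butoxy on that carbonyl carbon gives an 8.5-fold lower number from compound 3 to compound 4 (0.93 log units; beyond the scatter) and is the largest step so far. The (isopropylcarbonyl)amino chain also falls short of the two chains without it, with a 3.5-fold lower number from compound 2 to compound 4 (0.54 log units; beyond the scatter) and a 2.4-fold lower number from compound 1 to compound 4 (0.38 log units; beyond the scatter) as the steps, so at this position the group on the carbonyl carbon decides the read-out, not the carbonyl alone. Nothing available explains these steps.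

Two compounds cannot separate the oxygen of tert-butoxy from its carbon count. A tert-butylcarbonyl or an isopropoxycarbonyl on the same nitrogen would show which of the two goes with the difference.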